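The compounds below may be only part of what the source reports. "The series", "measured", "known", "first", "only" and "open" are said of these compounds alone.

Working notes on the series. Among the compounds with values here, compound 3 `C=C(Br)C(=O)Nc1ccc2c(c1)/C(=C/c1ccc[nH]1)C(=O)N2` stands lowest of the three numbers so far in a functional assay on MCF7 cells (Homo sapiens) for antiproliferative activity, read by MTT assay, with a stated time of 72 h (on this read-out higher numbers stand for weaker inhibition and lower numbers for stronger inhibition), where compound 3 gives 700 nM. Its nearest neighbour is compound 2 `C=C(Br)C(=O)Nc1ccc2c(c1)/C(=C\c1sccc1C)C(=O)N2`, which gives 2300 nM in this assay; the furthest is compound 1 `C#CC(=O)Nc1ccc2c(c1)/C(=C/c1ccc[nH]1)C(=O)N2`, which gives 3700 nM. Within the data shown here, the only single-point step measured is a 5.3-fold lower number from compound 1 to compound 3 (0.72 log units; beyond the scatter), and it concerns the group on the carbonyl carbon, not the ring at the other end of the molecule.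

Compound 4 `C=C(Br)C(=O)Nc1ccc2c(c1)/C(=C/c1ccc(C)s1)C(=O)N2` is not yet measured. It differs from compound 3 by 5-methylthiophen-2-yl in place of 1H-pyrrol-2-yl on a double-bonded chain carbon bound to a double-bonded ring carbon. Among the measured compounds shown here, no measured step bears on this ring exchange directly: compound 2 also carries a thiophene, but it differs from compound 3 in more than one place, so only its value and that of compound 3 can be set side by side, and they differ by a moderate amount. On that slim basis a small move toward a higher number is expected, a 2.0-fold higher number from compound 3 to compound 4 (0.30 log units; within the scatter), with wide uncertainty. Compound 4 is therefore estimated at 1400 nM, in the range 450 nM to 4500 nM.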

Compound 4, half-maximal inhibitory concentration: 3000 nM
For compound 4 the middle estimate is 2.1-fold (0.33 log units) below the measured one, and the stated range covers the measured number.
By their numbers in this assay, from the lowest: compound 3; then compounds 2, 4 and 1 (each within the scatter of the next).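

Within the data shown here, with the 1-bromoethenyl group held constant, the ring on the double-bonded chain carbon bound to a double-bonded ring carbon proves to matter in this assay, giving a 4.3-fold higher number from compound 3 to compound 4 (0.63 log units; beyond the scatter) as the first single-place step at this end of the molecule. The change from 1H-pyrrol-2-yl to 5-methylthiophen-2-yl exchanges the ring nitrogen for sulfur, removes the hydrogen-bond donor and adds a methyl group in one move, so this step cannot assign the rise to any one of these differences. Nothing available on these compounds explains the shift.

Unsubstituted thiophen-2-yl and 1-methylpyrrol-2-yl would separate the contribution of the methyl group from that of the ring exchange. Also open, going by these compounds, is whether a furan-2-yl ring or a pyrrole ring bearing a carboxylic acid would keep the number of compound 3 or raise it.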